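Removing the Trifluoromethyl Group from a Porcupine Inhibitor Series

The source may report more compounds than this note shows. Statements on the series, on what has been measured and on what is new or still open speak of the compounds shown alone.

Of the compounds shown here, three have been measured so far. Compound 1 `COc1ccccc1-n1nc(C(=O)NCC(=O)Nc2nc3ccccc3s2)c2ccccc2c1=O` gives 10000 nM in an assay on L cells for inhibition of Protein-serine O-palmitoleoyltransferase porcupine (Mus musculus), read by reporter gene assay, with a stated time of 24 h; a higher number here means that more compound is needed for the effect, a lower number that less compound is needed. Compound 2 `COc1ccc2nc(NC(=O)CNC(=O)c3nn(-c4ccccc4)c(=O)c4ccccc34)sc2c1` gives 210 nM in this assay. Compound 3 `O=C(CNC(=O)c1nn(-c2ccccc2)c(=O)c2ccccc12)Nc1nc2ccc(C(F)(F)F)cc2s1` gives 110 nM in this assay.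

Compound 3 has the lowest number of the three, but its distance from compound 2 lies within the scatter, so these two cannot be ranked against each other; compound 1 sits far above both. The next step leads to compound 4 `O=C(CNC(=O)c1nn(-c2ccccc2)c(=O)c2ccccc12)Nc1nc2ccccc2s1`, and the change is hydrogen in place of trifluoromethyl on an aromatic carbon. Within the data shown here, only one measured step touches this part of the molecule: a 1.9-fold lower number from compound 2 to compound 3 (0.28 log units; within the scatter), which exchanged one group for another there and stayed within the scatter. Among the measured compounds shown here, no measured step removes a group from that ring entirely. Compound 1 also lacks a group on that ring but differs from compound 4 elsewhere, so its value offers little guidance. The step is expected to be small, a 2.3-fold higher number from compound 3 to compound 4 (0.36 log units; beyond the scatter), within the scatter. Compound 4 is expected at 250 nM, in a range from 80 nM to 800 nM.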

Compound 4, half-maximal effective concentration: 2600 nM
The estimate for compound 4 lay 10-fold (1.02 log units) below the measured number; measured number outside the range, above it.
By their numbers in this assay, from the lowest: compounds 3 and 2 (each within the scatter of the next); then compound 4; then compound 1.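

In this assay, this carbon of the fused ring turns out not to be indifferent to what it carries: a bare hydrogen there costs far more than the earlier exchange of one group for another suggested (a 24-fold higher number from compound 3 to compound 4 (1.37 log units; beyond the scatter); a 12-fold higher number from compound 2 to compound 4 (1.09 log units; beyond the scatter)). Trifluoromethyl and methoxy, though very different groups, give numbers within the scatter of each other, and both stand well below the number with hydrogen. A methoxy at another place in the molecule behaves the opposite way, since losing it lowers the number (a 3.8-fold lower number from compound 1 to compound 4 (0.59 log units; beyond the scatter)), so the effect of removing methoxy depends on where it sits. Nothing available explains these differences.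

From the compounds shown here alone, whether an amine or a carboxylic acid on this carbon would match trifluoromethyl and methoxy stays open. So does whether a single fluorine atom would be enough.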